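Varying the Sulfonyl Substituent on a Shared Core

The compounds below may be only part of what the source reports. "The series", "measured", "known", "first", "only" and "open" are said of these compounds alone.

Two measured compounds share one core and differ only at the sulfonyl sulfur. Compound 1 `Cc1ccc(S(=O)(=O)N2CCN(C)CC2)cc1C#Cc1cc(Cl)ccc1OCC(=O)O` gives 21 nM in an assay on CHO cells for displacement of a labelled ligand from prostaglandin D2 receptor 2 (Homo sapiens), read by scintillation counting; a lower number here means a stronger inhibitor, a higher number a weaker inhibitor. Compound 2 `Cc1ccc(S(=O)(=O)CCO)cc1C#Cc1cc(Cl)ccc1OCC(=O)O` gives 19 nM in this assay, and the step of a 1.1-fold lower number from compound 1 to compound 2 (0.04 log units; within the scatter) lies within the scatter; compound 2 thus holds the lower of the two numbers, but only by a margin the scatter covers. Compound 3 `COCCNS(=O)(=O)c1ccc(C)c(C#Cc2cc(Cl)ccc2OCC(=O)O)c1` is not yet measured; it differs from compound 2 by (2-methoxyethyl)amino in place of 2-hydroxyethyl on a sulfonyl sulfur. Within the data shown here, the one measured step that bears on this position, a 1.1-fold lower number from compound 1 to compound 2 (0.04 log units; within the scatter), shows that exchanging the group on the sulfonyl sulfur left the number essentially unchanged. Compound 3 is therefore expected to stay close to compound 2. The step of a 1.2-fold higher number from compound 2 to compound 3 (0.06 log units; within the scatter) that this expectation means is estimated to lie within the scatter. In this assay compound 3 is estimated at 22 nM, within a range of 9 nM to 55 nM.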

Compound 3, inhibition constant: 3.6 nM
For compound 3 the middle estimate is 6.1-fold (0.79 log units) above the measured one; measured number outside the range, below it.
By their numbers in this assay, from the lowest: compound 3; then compounds 2 and 1 (each within the scatter of the next).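

In this assay, the group on the sulfonyl sulfur turns out to matter: (2-methoxyethyl)amino in place of 2-hydroxyethyl gives a 5.3-fold lower number from compound 2 to compound 3 (0.72 log units; beyond the scatter), and in place of 4-methylpiperazin-1-yl it gives a 5.8-fold lower number from compound 1 to compound 3 (0.77 log units; beyond the scatter). Compound 1 and compound 2 had stood within the scatter of each other, so the position looked indifferent until this change, and since compound 1 also carries a nitrogen on the sulfonyl sulfur, a nitrogen there is not enough by itself to give the lower number. Nothing available explains why this group does better.

On these data alone, it remains open whether the lower number depends on the nitrogen or on the terminal methoxy, which a (2-hydroxyethyl)amino group or a 3-methoxypropyl group on the sulfur would separate. As far as these compounds go, it is equally open how a longer chain such as (3-methoxypropyl)amino, or a terminal amine, would compare.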